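This account rests on a few compounds, and the source may have more. Where it says the series, first, only, none or still open, it means among the compounds named here.

Three compounds share one core and differ only in one group on the outer aromatic ring. In a functional assay on HT-29 cells (Homo sapiens) for cytotoxicity, read by MTT assay, with a stated time of 72 h (on this read-out lower numbers stand for stronger inhibition and higher numbers for weaker inhibition), compound 1 `CN(C)CCn1cnnc1-c1cc(Oc2ccc(NC(=O)N/N=C/c3ccc(F)cc3)cc2F)ccn1` gives 1370 nM; compound 2 `CN(C)CCn1cnnc1-c1cc(Oc2ccc(NC(=O)N/N=C/c3ccc(Cl)cc3)cc2F)ccn1` gives 530 nM; compound 3 `CN(C)CCn1cnnc1-c1cc(Oc2ccc(NC(=O)N/N=C/c3ccc(O)cc3)cc2F)ccn1` gives 1920 nM. Compound 3 holds the highest number of the three: the step of a 3.6-fold higher number from compound 2 to compound 3 (0.56 log units; beyond the scatter) lies beyond the scatter, whereas a 1.4-fold higher number from compound 1 to compound 3 (0.15 log units; within the scatter) lies within it, so compound 3 and compound 1 cannot be told apart. The unmeasured compound 4 `CN(C)CCn1cnnc1-c1cc(Oc2ccc(NC(=O)N/N=C/c3ccc(O)c(F)c3)cc2F)ccn1` differs from compound 3 by fluoro in place of hydrogen on an aromatic carbon. Going by the values given here, no measured step adds a group while the hydroxy group stays in place, so the guidance is indirect: the step of a 1.4-fold higher number from compound 1 to compound 3 (0.15 log units; within the scatter) shows that exchanging fluoro for hydroxy changes little, and a 2.6-fold lower number from compound 1 to compound 2 (0.41 log units; beyond the scatter) shows that a swap from one halogen to another can move the number modestly. On that basis the expected step is a 1.4-fold lower number from compound 3 to compound 4 (0.14 log units; within the scatter), which amounts to no clear change beyond the scatter. Compound 4 is therefore estimated at 1400 nM, with a range from 500 nM to 4000 nM.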

Compound 4, half-maximal inhibitory concentration: 3310 nM
Compound 4: middle estimate off by 2.4-fold (0.37 log units), on the low side; measured number inside the range.
By their numbers in this assay, from the lowest: compound 2; then compounds 1, 3 and 4 (each within the scatter of the next, the first and the last beyond it).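

In this assay, fluoro on the aromatic carbon ortho to the hydroxy group gives the step of a 1.7-fold higher number from compound 3 to compound 4 (0.24 log units; within the scatter) and so causes no clear change at this position. Even so, the 3-fluoro-4-hydroxyphenyl group can be told apart from both halogen-only rings, which the 4-hydroxyphenyl group managed against 4-chlorophenyl alone: replacing 4-fluorophenyl gives a 2.4-fold higher number from compound 1 to compound 4 (0.38 log units; beyond the scatter) and replacing 4-chlorophenyl gives a 6.2-fold higher number from compound 2 to compound 4 (0.80 log units; beyond the scatter) and both steps lie beyond the scatter. No measurement available here explains these numbers.

From the compounds shown here alone, it remains open whether the same fluoro would behave alike on a ring without the hydroxy group. Also open, going by these compounds, is how a methoxy group or an amine would fare in place of the hydroxy group.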